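Replacing tert-butoxycarbonyl with hydrogen at the assay limit

A few compounds are considered here, and "the series" means these few. Any claim that something is new, unique, unknown or untested is made for them only; others in the source may bear on it.

Measured in a functional assay on MCF7 cells (Homo sapiens) for antiproliferative activity, read by MTT assay, with a stated time of 48 h; on this read-out lower numbers stand for stronger inhibition and higher numbers for weaker inhibition (each value is a limit):
Compound 1 `COC1=CC(=O)N(C(=O)/C=C/[C@H](C)NC(=O)[C@H](CC(C)C)N(C)C)[C@H]1Cc1ccccc1` gives > 100000 nM (a limit)
Compound 2 `CC[C@H](C)[C@H](NC(=O)OCc1ccccc1)C(=O)N[C@@H](CC(C)C)C(=O)N[C@@H](CC(C)C)C(=O)N[C@@H](C)/C=C/C(=O)N1C(=O)C=C(OC)[C@@H]1c1cn(C(=O)OC(C)(C)C)c2ccccc12` gives > 100000 nM (a limit)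

For compound 2 the result is a limit, > 100000 nM and not a number. Compound 3 `CC[C@H](C)[C@H](NC(=O)OCc1ccccc1)C(=O)N[C@@H](CC(C)C)C(=O)N[C@@H](CC(C)C)C(=O)N[C@@H](C)/C=C/C(=O)N1C(=O)C=C(OC)[C@@H]1c1c[nH]c2ccccc12` differs from compound 2 in one place: hydrogen in place of tert-butoxycarbonyl on an aromatic nitrogen. In this assay, among the measured compounds shown here, no measured step between compounds gauges this change. A small gain in strength is therefore expected at most, and compound 3 may well stay at the limit, since compound 2 at > 100000 nM offers no number to start from. The expected change is an at least 1.4-fold lower number from compound 2 to compound 3 (0.15 log units; that floor lies within the scatter) and it is only a rough expectation. For compound 3 the estimated value is 70000 nM with an expected range from 20000 nM to 200000 nM in this reading.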

Compound 3, half-maximal inhibitory concentration: > 100000 nM
Compound 3 ended at the assay's limit; the forecaster's own chance of this, stated with the estimate: 60%; middle value at least 1.4-fold (0.15 log units) from the limit.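

No step from compound 2 to compound 3 can be read in this assay, because both results are limits and not numbers: the limit of > 100000 nM in this assay, at which 3 of the 3 values shown sit.

The compounds shown leave open whether hydrogen in place of tert-butoxycarbonyl on an aromatic nitrogen changes the strength of inhibition at all.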